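Benzyl in place of cyclohexyl on an amide-type nitrogen

The source may report more compounds than this note shows. Statements on the series, on what has been measured and on what is new or still open speak of the compounds shown alone.

In a functional assay on the whole organism with Mus musculus as the target, in the maximal electroshock model, with a stated time of 30 min (on this read-out higher numbers stand for an effect only at larger amounts of compound and lower numbers for an effect already at smaller amounts), compound 1 `CC(C)(C)NC(=O)CNC(=O)OCc1ccccc1` gives 39.4 mg/kg as its dose for half-maximal effect. Compound 2 `O=C(CNC(=O)OCc1ccccc1)NC1CCCCC1` gives 33.4 mg/kg on the same read-out, so it stands within the scatter of compound 1 and the two cannot be ranked. Compound 3 `O=C(CNC(=O)OCc1ccccc1)NCc1ccccc1` keeps the core of compound 2 and carries benzyl in place of cyclohexyl on an amide-type nitrogen. A six-membered aromatic ring of carbon only thus replaces a non-aromatic one.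

Within the data shown here, only one measured step bears on this place: a 1.2-fold lower number from compound 1 to compound 2 (0.07 log units; within the scatter), for cyclohexyl in place of tert-butyl. Among the measured compounds shown here, no measured compound carries an aromatic group on this nitrogen, so this single step is thin evidence and the range has to stay wide. On the strength of that step, no change beyond the scatter is expected in this assay and no direction is favoured. The estimated step is a 1.1-fold lower number from compound 2 to compound 3 (0.05 log units; within the scatter) and it remains an expectation only. For compound 3 the estimated value is 30 mg/kg, with an expected range from 12 mg/kg to 70 mg/kg.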

Compound 3, dose for half-maximal effect: 4.8 mg/kg
The estimate for compound 3 lay 6.3-fold (0.80 log units) above the measured number; the measured number lies below the stated range.
By their numbers in this assay, from the lowest: compound 3; then compounds 2 and 1 (each within the scatter of the next).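

In this assay the group on this amide-type nitrogen proves able to move the number well beyond the scatter, which the step from tert-butyl to cyclohexyl did not show: benzyl in place of cyclohexyl gives a clear drop (a 7.0-fold lower number from compound 2 to compound 3 (0.84 log units; beyond the scatter)), and benzyl in place of tert-butyl gives one of similar size (an 8.2-fold lower number from compound 1 to compound 3 (0.91 log units; beyond the scatter)). Within these three compounds, the two with a non-aromatic carbon group on the nitrogen, compound 1 and compound 2, cannot be ranked, and only compound 3, with its six-membered aromatic ring of carbon only, stands apart from both, so this separation rests on a single compound. No measurement shown gives a reason for this drop.

Benzyl differs from cyclohexyl both in its aromatic ring and in its count of heavy atoms, so the present step cannot assign the drop to either difference, and cyclohexylmethyl or phenyl on the same nitrogen would pull the two apart. Also open, as far as these compounds go, is whether the lower number holds for a longer chain to the ring, such as 2-phenylethyl, or for a benzyl group carrying fluorine or methoxy on its ring.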